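This account rests on a few compounds, and the source may have more. Where it says the series, first, only, none or still open, it means among the compounds named here.

Measured so far in an ADME assay on THP-1 cells (Homo sapiens) for cytotoxicity; a higher number here means a weaker inhibitor, a lower number a stronger inhibitor:
compound 1 `COc1ccccc1-c1nnc(-c2ccc(C(=O)N/N=C/c3ccc([N+](=O)[O-])cc3)cc2)o1` gives 203000 nM;
compound 2 `COc1ccc(/C=N/NC(=O)c2ccc(-c3nnc(-c4ccccc4OC)o3)cc2)cc1O` gives 260000 nM;
compound 3 `COc1ccc(O)c(/C=N/NC(=O)c2ccc(-c3nnc(-c4ccccc4OC)o3)cc2)c1` gives 303000 nM.

Compound 3 has the highest of these three numbers, yet its steps from the others are small: a 1.5-fold higher number from compound 1 to compound 3 (0.17 log units; within the scatter) and a 1.2-fold higher number from compound 2 to compound 3 (0.07 log units; within the scatter), so the three cannot be told apart in this assay. Compound 4 `COc1ccc(/C=N/NC(=O)c2ccc(-c3nnc(-c4ccccc4OC)o3)cc2)c(O)c1` differs from compound 3 by 2-hydroxy-4-methoxyphenyl in place of 2-hydroxy-5-methoxyphenyl on a carbon with a double bond to nitrogen. The step that bears most on this is a 1.2-fold higher number from compound 2 to compound 3 (0.07 log units; within the scatter), where one arrangement of hydroxy and methoxy gave way to another; the steps of a 1.3-fold higher number from compound 1 to compound 2 (0.11 log units; within the scatter) and a 1.5-fold higher number from compound 1 to compound 3 (0.17 log units; within the scatter) point the same way. Every change at this carbon so far stayed within the scatter, so compound 4 is expected to move no further, with a 1.0-fold lower number from compound 3 to compound 4 (0.00 log units; within the scatter). Compound 4 is estimated at 300000 nM, likely between 150000 nM and 600000 nM.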

Compound 4, half-maximal inhibitory concentration: 308000 nM
The estimate for compound 4 lay 1.0-fold (0.01 log units) below the measured number; the range from low to high includes it.
By their numbers in this assay, from the lowest: compounds 1, 2, 3 and 4 (each within the scatter of the next).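

In this assay, 2-hydroxy-4-methoxyphenyl in place of 2-hydroxy-5-methoxyphenyl on a carbon with a double bond to nitrogen gives a 1.0-fold higher number from compound 3 to compound 4 (0.01 log units; within the scatter) and so leaves the number within the scatter. A third arrangement of the same hydroxy and methoxy groups also stays within the scatter, with a 1.2-fold higher number from compound 2 to compound 4 (0.07 log units; within the scatter) and, in place of 4-nitrophenyl, a 1.5-fold higher number from compound 1 to compound 4 (0.18 log units; within the scatter) as the largest new step. No supporting data explain why these numbers stay so close. From the compounds shown here alone, whether an amine or a carboxylic acid on the phenyl group at this carbon would produce a step beyond the scatter remains open.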